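The compounds below may be only part of what the source reports. "The series", "measured", "known", "first", "only" and "open" are said of these compounds alone.

Of the compounds shown here, two built on one shared core have been measured in an assay on CHO cells for displacement of a labelled ligand from adenosine receptor A3 (Homo sapiens), read by scintillation counting, with a stated time of 45 min, tested at 1 uM, in the presence of a further agent that is not named here; on this read-out higher numbers stand for more inhibition at the one concentration tested (going by the name of the read-out) and lower numbers for less inhibition. Compound 1, `CCCn1c(=O)[nH]c2nc(-c3ccc(S(=O)(=O)N4CCN(c5cccc(Br)c5)CC4)cc3)[nH]c2c1=O`, gives 27% in this assay. Compound 2, `CCCn1c(=O)[nH]c2nc(-c3ccc(S(=O)(=O)N4CCN(c5ccc(I)cc5)CC4)cc3)[nH]c2c1=O`, gives 36% in this assay. For the measured compounds named here, compound 2 holds the higher of the two numbers, with compound 1 as its only neighbour, but the single measured step, a number 9 percentage points higher from compound 1 to compound 2 (within the scatter), lies within the scatter, so the two numbers do not separate the compounds. Compound 3, `CCCn1c(=O)[nH]c2nc(-c3ccc(S(=O)(=O)N4CCN(Cc5ccc(Br)cc5)CC4)cc3)[nH]c2c1=O`, has not yet been measured. It differs from compound 2 by 4-bromobenzyl in place of 4-iodophenyl on an amine nitrogen in a ring. Going by the values given here, no measured step matches this change exactly; the only guide is the step from compound 1 to compound 2, which also replaces the group on an amine nitrogen in a ring, and that step was small. Among the compounds with values here, because the only comparable step, a number 9 percentage points higher from compound 1 to compound 2 (within the scatter), stayed within the scatter, a step of similar size and no settled direction is all the data support. The expected step is a number 6 percentage points lower from compound 2 to compound 3 (within the scatter), within the scatter. Compound 3 is therefore estimated to give 30% in this assay, with a range from 10% to 50%.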

Compound 3, a percentage reported as inhibition, at one concentration (the size of the read-out at that concentration, not a potency): 28%
The estimate for compound 3 lay 2 percentage points above the measured number; the measured number falls inside the stated range.
By their numbers in this assay, from the lowest: compounds 1, 3 and 2 (each within the scatter of the next).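

The result adds a different kind of group at this position, on an amine nitrogen in a ring: with 4-bromobenzyl, the aromatic ring no longer sits directly on that nitrogen, as it does in the two aryl compounds. Set against 4-iodophenyl, this change gives a number 8 percentage points lower from compound 2 to compound 3 (within the scatter) in this assay and set against 3-bromophenyl it gives a number 1 percentage points higher from compound 1 to compound 3 (within the scatter) so the three groups tried at this nitrogen do not separate on this read-out, whether the ring is attached directly or through the benzyl carbon. No measurement shown here offers an explanation for these small steps.

The compounds shown leave open whether a group of another kind on this nitrogen, such as a simple alkyl chain, a carboxylic acid or an amine, would move the number beyond the scatter. They also leave open how these compounds compare in potency, as each was read at a single concentration, and what a change on the shared core, away from this nitrogen, would do.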